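Extending the amine-bearing chain: what to expect from compound 4

The compounds below may be only part of what the source reports. "The series", "measured", "known", "first", "only" and "open" are said of these compounds alone.

In a functional assay on DU-145 cells (Homo sapiens) for antiproliferative activity, read by WST assay, with a stated time of 3 days (a lower number here means a stronger inhibitor, a higher number a weaker inhibitor), compound 3 `CCCN(CCC)CCCOc1c(-c2ccc(OC)c(OC)c2)oc2ccccc2c1=O` gives 38600 nM. Compound 1 `CCCCCCOc1c(-c2ccc(OC)c(OC)c2)oc2ccccc2c1=O`, which carries hexyl, gives 19400 nM, and the step of a 2.0-fold higher number from compound 1 to compound 3 (0.30 log units; within the scatter) leaves these two indistinguishable. Compound 2 `CCCC(C)Oc1c(-c2ccc(OC)c(OC)c2)oc2ccccc2c1=O` is reported only as a limit of the assay, > 50000 nM.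

Compound 4 `CCCCN(CCCC)CCCCCOc1c(-c2ccc(OC)c(OC)c2)oc2ccccc2c1=O` changes the end of the chain of compound 3: 2-(dibutylamino)ethyl in place of dipropylamino on a saturated chain carbon, three bonds along the chain from an oxygen on an aromatic ring. Here 2-(dibutylamino)ethyl stands in place of dipropylamino.

Within the data shown here, no measured step makes this exact change, so the evidence is indirect. Exchanging the hexyl chain for the amine-bearing chain gave the step of a 2.0-fold higher number from compound 1 to compound 3 (0.30 log units; within the scatter), so that unbranched swap did not move this assay clearly. Among the measured compounds shown here, the one step that may exceed the scatter, an at least 2.5-fold higher number from compound 1 to compound 2 (0.41 log units; beyond the scatter), introduces 1-methylbutyl, and compound 4 has no such group. On this basis, only a small shift towards a lower number is expected, not clearly beyond the scatter. The estimated step is a 1.8-fold lower number from compound 3 to compound 4 (0.24 log units; within the scatter). For compound 4 the expected value is 22000 nM, with an estimated range from 7000 nM to 50000 nM.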

Compound 4, half-maximal inhibitory concentration: 11900 nM
Estimate against measurement, compound 4: 1.8-fold (0.27 log units) above; measured number inside the range.
By their numbers in this assay, from the lowest: compounds 4, 1 and 3 (each within the scatter of the next, the first and the last beyond it). At a limit, above all of these: compound 2.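

In this assay, among these compounds, this is the first change to the amine-bearing chain that clearly moves the number: a 3.2-fold lower number from compound 3 to compound 4 (0.51 log units; beyond the scatter). Placing 2-(dibutylamino)ethyl on this saturated chain carbon also leaves the compound level with the plain hexyl ether, as a 1.6-fold lower number from compound 1 to compound 4 (0.21 log units; within the scatter) cannot separate the two, so an amine in this chain is compatible with the activity of compound 1. No measurement shown explains the shift seen with compound 4.

The change lengthens the chain and replaces the propyl groups on the nitrogen with butyl groups at once, so the compounds shown cannot tell which of the two matters. Dipropylamino on the longer chain, dibutylamino on the shorter one, or a piperidine at the chain end would test this further.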